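Amide-to-amine swap on a hydroxamate series

The compounds below may be only part of what the source reports. "The series", "measured", "known", "first", "only" and "open" are said of these compounds alone.

Measured compounds:
compound 1 `COCCNC(=O)C[C@H](NC(=O)c1ccc(C#Cc2ccccc2)cc1)C(=O)NO` — 2
compound 2 `O=C(NC1(C(=O)NO)CCOCC1)c1ccc(C#Cc2ccccc2)cc1` — > 4

Among the measured compounds shown here, in a physicochemical assay for lipophilicity (a higher number here means a more lipophilic compound, a lower number a more polar compound), compound 1 gives 2, the only plain number in the set. For compound 2 the result is a limit of this assay, > 4, and not a number. For the measured compounds named here, the other entry is thus (the limit of > 4 in this assay, at which 1 of the 2 values shown sits), so no measured step between two numbers exists here and the scatter cannot be checked against a real comparison; compound 1 stands alone as the one fixed point.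

Compound 3 `NC[C@H](NC(=O)c1ccc(C#Cc2ccccc2)cc1)C(=O)NO` has not yet been measured. It differs from compound 1 in one place, (amino in place of (2-methoxyethyl)carbamoyl on a saturated chain carbon, two bonds along the chain from an amide-type nitrogen and a carbonyl carbon). The change is amino in place of (2-methoxyethyl)carbamoyl on a saturated chain carbon, two bonds along the chain from an amide-type nitrogen and a carbonyl carbon; the shared core is unchanged.

Going by the values given here, with no measured step available, the expectation rests on the structural change alone: a step downward, beyond the usual scatter, is expected from compound 1 to compound 3, of about a number 1.30 log units lower from compound 1 to compound 3 (beyond the scatter). For compound 3 the estimated distribution coefficient in this assay is 0.7, with a range from -0.3 to 1.7.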

Compound 3, distribution coefficient: 2
The estimate for compound 3 lay 1.30 log units below the measured number; the measured number lies above the stated range.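

Read in this assay the only step between two numbers in the set is no change at the digits printed from compound 1 to compound 3 (within the scatter) for amino in place of (2-methoxyethyl)carbamoyl on a saturated chain carbon, two bonds along the chain from an amide-type nitrogen and a carbonyl carbon. This gives the position its first real comparison: the group that leaves has 7 heavy atoms and the group that enters has 1, and in this pair that large cut in heavy atoms comes with a read-out that stays within the scatter. Nothing measured here accounts for that outcome.

Whether a carboxylic acid or a longer chain ending in a hydroxyl group at this place would also stay within the scatter of compound 1 is open, and a single pair sets no trend for the position. Compound 2 differs from compound 1 in more than one place and gives a limit, not a number: the limit of > 4 in this assay, at which 1 of the 3 values shown sits.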